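The source may hold more compounds than are shown below. What is called first, only, known or untested is meant among the compounds shown, and "the series" means these compounds.

Compound 1 `C#CC(=O)N1C(c2cccc(F)c2)SC[C@@H]1C(=O)OCC` carries a 3-fluorophenyl group on its saturated ring carbon, and in a functional assay on MV cells (Homo sapiens) for inhibition, read by sulforhodamine B assay (on this read-out higher numbers stand for weaker inhibition and lower numbers for stronger inhibition), compound 1 gives 1700 nM, the highest of the three numbers here. Compound 3 `C#CC(=O)N1C(c2ccccc2)SC[C@@H]1C(=O)OCC` differs from it only by a hydrogen in place of the fluoro on the aromatic ring, and compound 3 gives 400 nM; the step of a 4.3-fold lower number from compound 1 to compound 3 (0.63 log units; beyond the scatter) lies beyond the scatter. Compound 2 `C#CC(=O)N1C(CC(C)CC(C)(C)C)SC[C@@H]1C(=O)OCC` instead carries a branched alkyl chain at that position and gives 1100 nM, which sits within the scatter of compound 1. Compound 4 `C#CC(=O)N1C(CCCCC)SC[C@@H]1C(=O)OCC` makes the change (pentyl in place of 3-fluorophenyl on a saturated ring carbon). Only compound 2 speaks to an alkyl chain at this place, and its number shows no clear shift from compound 1. Compound 4 is therefore expected to give about 1200 nM, between 450 nM and 3200 nM, a step of a 1.4-fold lower number from compound 1 to compound 4 (0.15 log units; within the scatter) expected to remain within the scatter.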

Compound 4, half-maximal inhibitory concentration: 2000 nM
Compound 4: middle estimate off by 1.7-fold (0.22 log units), on the low side; the range from low to high includes it.
By their numbers in this assay, from the lowest: compound 3; then compounds 2, 1 and 4 (each within the scatter of the next).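

Pentyl in place of 3-fluorophenyl leaves the number within the scatter (a 1.2-fold higher number from compound 1 to compound 4 (0.07 log units; within the scatter)), and so does removing the branches from the chain (a 1.8-fold higher number from compound 2 to compound 4 (0.26 log units; within the scatter)). Pentyl in place of phenyl, however, weakens inhibition (a 5.0-fold higher number from compound 3 to compound 4 (0.70 log units; beyond the scatter)), so an aromatic ring does not by itself beat an alkyl chain here, and compound 1 goes against any such rule. No measurement shown explains this difference. Open, on these data alone, is whether a longer chain, or a phenyl ring carrying methoxy, would stay near compound 4 or approach compound 3.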